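Isobutyl for sec-butyl on the benzyl ester side chain

The source may report more compounds than this note shows. Statements on the series, on what has been measured and on what is new or still open speak of the compounds shown alone.

The series is followed in a functional assay on the whole organism (Tail, strain ICR) with Mus musculus as the target, in the tail flick test, with a stated time of 60 min, at a dose of 25 umol/kg by the oral route; a higher number here means a stronger effect of the compound at the dose given, a lower number a weaker effect. Three compounds carry numbers. Compound 1 `N=C(N)NCCC[C@H](NC(=O)CN(c1nc(Cl)nc2[nH]cnc12)C1CC1)C(=O)O` gives 51%. Compound 2 `CC[C@H](C)[C@H](NC(=O)CN(c1ncnc2c1ncn2C1CCCCO1)C1CC1)C(=O)OCc1ccccc1` gives 27.4%. Compound 3 `O=C(OCc1ccccc1)[C@@H]1CCCN1C(=O)CN(c1ncnc2c1ncn2C1CCCCO1)C1CC1` gives 36.7%. Compound 2 and compound 3 sit within the scatter of each other, so their two numbers are not told apart here; compound 1 stands beyond the scatter above compound 2. For the measured compounds named here, no two of the measured compounds differ in one place only, so no measured step is at hand to lean on.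

Compound 4 `CC(C)C[C@H](NC(=O)CN(c1ncnc2c1ncn2C1CCCCO1)C1CC1)C(=O)OCc1ccccc1` is the next member, not yet measured in this assay. Compared with compound 2 it changes as follows: isobutyl in place of sec-butyl on a saturated chain carbon bound to an amide-type nitrogen and a carbonyl carbon. The two compounds hold the same atoms, joined differently, and the change touches nothing beyond that side chain.

Going by the values given here, with no measured step to guide the size, the expectation for compound 4 is set at the number of compound 2, and the step of a number 0.6 percentage points higher from compound 2 to compound 4 (within the scatter) is expected to stay within the scatter, in no particular direction. Compound 4 is therefore estimated at 28% in this assay, with a likely range from 15% to 42%, pending the measurement.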

Compound 4, a percentage reported as activity, at one dose (the size of the read-out at that dose, not a potency): 34.2%
Compound 4: middle estimate off by 6.2 percentage points, on the low side, within the range that was stated.
By their numbers in this assay, from the lowest: compounds 2, 4 and 3 (each within the scatter of the next); then compound 1.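

The exchange of sec-butyl for isobutyl on a saturated chain carbon bound to an amide-type nitrogen and a carbonyl carbon gives the series its first step between two measured compounds. In this assay the step of a number 6.8 percentage points higher from compound 2 to compound 4 (within the scatter) shows that this rearrangement of the same carbon atoms, which also removes the defined stereocentre of sec-butyl, leaves the two compounds not told apart at this dose and time. No measurement that would explain this outcome is at hand.

Open, on these data alone, is whether this position stays as undemanding when the side chain is no longer a four-carbon alkyl group, for instance with a hydroxyl, a primary amine or a longer chain such as n-hexyl. For the compounds shown here, also open is whether sec-butyl and isobutyl remain indistinguishable once the pair is followed at other doses or times, since a single-dose read-out at one time gives no potency for either compound.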